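Replacing 2-bromobenzyl with 3-methylbenzyl on the shared core

This account rests on a few compounds, and the source may have more. Where it says the series, first, only, none or still open, it means among the compounds named here.

Two compounds sharing one core open this account, and neither supplies a single number. In a functional assay on G-361 cells (Homo sapiens) for antiproliferative activity, with a stated time of 72 h (on this read-out lower numbers stand for stronger inhibition and higher numbers for weaker inhibition), compound 1 `OC[C@H]1O[C@@H](n2cnc3c(NCc4ccccc4Cl)ncnc32)[C@H](O)[C@@H]1O` carries the entry "not determined" (no result reported). Compound 2 `OC[C@H]1O[C@@H](n2cnc3c(NCc4ccccc4Br)ncnc32)[C@H](O)[C@@H]1O` is recorded at > 166000 nM, which is a limit of the assay and not a number. Within the data shown here, the only firm reading so far is therefore (the limit of > 166000 nM in this assay, at which 1 of the 2 values shown sits), and compound 2 has no exact place on the scale.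

Compound 3 `Cc1cccc(CNc2ncnc3c2ncn3[C@@H]2O[C@H](CO)[C@@H](O)[C@H]2O)c1` comes next, and its difference from compound 2 is 3-methylphenyl in place of 2-bromophenyl on a saturated chain carbon bound to a nitrogen on an aromatic ring. Put plainly, 3-methylphenyl stands in place of 2-bromophenyl on a saturated chain carbon bound to a nitrogen on an aromatic ring.

Among the measured compounds shown here, no step between measured compounds is available to size this change in this assay. Since compound 2 sits at > 166000 nM the only room for a clearly visible move is toward stronger inhibition, and a clear move is expected, though with wide uncertainty. The estimated change is an at least 4.1-fold lower number from compound 2 to compound 3 (0.61 log units; beyond the scatter). For compound 3 the expected value is 40000 nM, with an estimated range from 3000 nM to 170000 nM.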

Compound 3, half-maximal inhibitory concentration: > 166000 nM
Compound 3: no number, only a limit; the forecaster's own chance of this, stated with the estimate: 40%; at least 4.1-fold (0.61 log units) between middle value and limit.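

In this assay compound 3 gives > 166000 nM as its entry, which is a limit of the assay and not a number. Among these compounds, compound 2 also carries only a limit, so no step from compound 2 to compound 3 can be read. The compounds shown leave open whether 2-bromobenzyl and 3-methylbenzyl differ at all in this assay and where on its scale either compound truly lies.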